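Carbamoyl in Place of Trifluoromethyl: Estimating Compound 3

The source may report more compounds than this note shows. Statements on the series, on what has been measured and on what is new or still open speak of the compounds shown alone.

Measured so far:
compound 1, `Cc1c(C(=O)NCc2cccc(C(F)(F)F)c2)cnn1-c1ccc(Cl)cc1`: 600 nM
compound 2, `Cc1c(C(=O)NCc2cccc(C(F)(F)F)c2)cnn1Cc1ccccc1`: > 3000 nM

Of the compounds shown here, two have been measured in a functional assay on cells for antagonist activity at C-C chemokine receptor type 1 (Homo sapiens), read by FLIPR and calcium flux; a higher number here means a weaker inhibitor, a lower number a stronger inhibitor. Going by the values given here, compound 1 gives 600 nM, the only real number among the two values. For compound 2 the assay reports only a limit, > 3000 nM. Among the compounds with values here, the one measured step, an at least 5.0-fold higher number from compound 1 to compound 2 (0.69 log units; beyond the scatter), concerns the group on the aromatic nitrogen and reaches (the limit of > 3000 nM in this assay, at which 1 of the 2 values shown sits).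

The change under consideration leads to compound 3 `Cc1c(C(=O)NCc2cccc(C(N)=O)c2)cnn1-c1ccc(Cl)cc1`: carbamoyl in place of trifluoromethyl on an aromatic carbon. Within the data shown here, this position is untouched in any measured pair, so no measured step bears on it, and the expectation rests on the change alone. A weaker inhibitor is expected, with an estimated step of a 3.3-fold higher number from compound 1 to compound 3 (0.52 log units; beyond the scatter). Compound 3 is therefore estimated at 2000 nM, with a range from 500 nM to 6000 nM.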

Compound 3, half-maximal inhibitory concentration: > 3000 nM
Compound 3: a limit, no number; the forecaster's own chance of this, stated with the estimate: 35%; at least 1.5-fold (0.17 log units) between middle value and limit.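

Trifluoromethyl proves to be more than a replaceable group at this position, on an aromatic carbon of a six-membered aromatic ring of carbon only: in this assay, carbamoyl in its place gives an at least 5.0-fold higher number from compound 1 to compound 3 (0.69 log units; beyond the scatter). Compound 1 had until now shown only that the group on the aromatic nitrogen matters, whereas this step shows that the group at this second place on the molecule matters as well. Compound 3 gives > 3000 nM, which is a limit and not a number, so the full size of the loss cannot be read: the limit of > 3000 nM in this assay, at which 2 of the 3 values shown sit.

The compounds shown leave open whether a nitrile, a methyl ester or a chlorine atom at this place would keep the activity of compound 1. They also leave open whether a simple hydrogen there would do so.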